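The source may report more compounds than this note shows. Statements on the series, on what has been measured and on what is new or still open speak of the compounds shown alone.

Of the compounds shown here, three measured so far share one core and differ in the group carried on the double-bonded chain. In a physicochemical assay for lipophilicity, using the shake flask method (a lower number here means a more polar compound, a higher number a more lipophilic compound), compound 1 (`C[C@H](Oc1ccc2ncc(/C=C/c3nn[nH]n3)c(C3CC3)c2c1)c1c(Cl)ccc(F)c1Cl`) gives 3.7 as its reading, compound 2 (`C[C@H](Oc1ccc2ncc(/C=C/C(=O)O)c(C3CC3)c2c1)c1c(Cl)ccc(F)c1Cl`) gives 4.1 as its reading, and compound 3 (`C[C@H](Oc1ccc2ncc(/C=C/C(=O)NC(CC(=O)O)CC(=O)O)c(C3CC3)c2c1)c1c(Cl)ccc(F)c1Cl`) gives 0.4 as the lowest reading of the three.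

Compound 4 (`C[C@H](Oc1ccc2ncc(/C=C/C(=O)N3CC[C@@H](N)[C@H](C(=O)O)C3)c(C3CC3)c2c1)c1c(Cl)ccc(F)c1Cl`) keeps the core and the carbonyl but exchanges the group attached there, and the change is a group of 10 heavy atoms (6 carbon, 2 nitrogen, 2 oxygen; one six-membered non-aromatic ring with 1 hetero atom) in place of a group of 10 heavy atoms (5 carbon, 1 nitrogen, 4 oxygen; no ring), on a carbonyl carbon in full. In short, a group with a six-membered non-aromatic ring replaces the open-chain (2-carboxy-1-(carboxymethyl)ethyl)amino group on a carbonyl carbon.

The most relevant evidence is the arrival of that leaving group, with a number 3.70 log units lower from compound 2 to compound 3 (beyond the scatter) as a large step, and a number 3.30 log units lower from compound 1 to compound 3 (beyond the scatter) is large too. By contrast, a number 0.40 log units higher from compound 1 to compound 2 (beyond the scatter) is only modest. Among the measured compounds shown here, removing the group may therefore win back part of the large drop seen for compound 3, but no measured compound carries the entering ring, so a full return is not assumed.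

A sizeable upward move is expected, estimated as a number 1.60 log units higher from compound 3 to compound 4 (beyond the scatter) in this assay with real uncertainty. Compound 4 is estimated at 2 with an expected range from 1 to 3 on this scale.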

Compound 4, distribution coefficient: 3.1
Estimate against measurement, compound 4: 1.10 log units below, and the stated range ends below it.
By their numbers in this assay, from the lowest: compound 3; then compound 4; then compound 1; then compound 2.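

In this assay, the step on the carbonyl carbon is a number 2.70 log units higher from compound 3 to compound 4 (beyond the scatter), even though the leaving (2-carboxy-1-(carboxymethyl)ethyl)amino group and the entering group with its six-membered non-aromatic ring have the same heavy-atom count, so at this position the count alone does not set the reading. Among the compounds shown here, the earlier compounds showed only that this open-chain group came with a large drop, whereas the ring-bearing group stays much closer to the smaller groups, with a number 1.00 log units lower from compound 2 to compound 4 (beyond the scatter) and a number 0.60 log units lower from compound 1 to compound 4 (beyond the scatter), both modest steps. No measured evidence here explains why the two groups differ so much.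

The compounds shown leave open how much of the reading comes from the ring itself and how much from the groups on it: the same six-membered ring carrying only an amine or only a carboxylic acid would separate these, as would an open chain carrying an amine. No pair shown differs only at the 2 defined stereocentres of the entering group, so any part they play also remains open.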